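A Methoxyphenyl Swap on Compound 3

A few compounds are considered here, and "the series" means these few. Any claim that something is new, unique, unknown or untested is made for them only; others in the source may bear on it.

In a functional assay on HeLa cells (Homo sapiens) for antiproliferative activity, read by MTT assay, with a stated time of 72 h (a higher number here means a weaker inhibitor, a lower number a stronger inhibitor), compound 1 (`COc1cc(C(=O)c2sc3ccccc3c2-c2ccc(Cl)cc2)cc(OC)c1OC`) gives 5200 nM, compound 2 (`COc1cc(C(=O)c2sc3ccccc3c2-c2ccc(C)cc2)cc(OC)c1OC`) gives 3700 nM and compound 3 (`COc1cc(C(=O)c2sc3ccccc3c2-c2ccc(SC)cc2)cc(OC)c1OC`) gives 3500 nM. Compound 3 therefore sits level with the other two, as a 1.5-fold lower number from compound 1 to compound 3 (0.17 log units; within the scatter) and a 1.1-fold lower number from compound 2 to compound 3 (0.02 log units; within the scatter) are both within the scatter, as is a 1.4-fold lower number from compound 1 to compound 2 (0.15 log units; within the scatter). Compound 4 (`COc1ccccc1-c1c(C(=O)c2cc(OC)c(OC)c(OC)c2)sc2ccccc12`) has 2-methoxyphenyl in place of 4-(methylsulfanyl)phenyl on an aromatic carbon. Those three steps changed only a small group on the phenyl ring, so they offer limited guidance for this larger swap. A small move to a higher number is expected, namely a 1.4-fold higher number from compound 3 to compound 4 (0.15 log units; within the scatter). For compound 4, the estimated value is 5000 nM, with an expected range from 1500 nM to 15000 nM.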

Compound 4, half-maximal inhibitory concentration: 5000 nM
For compound 4 middle estimate and measured number coincide at the digits printed; the measured number falls inside the stated range.
By their numbers in this assay, from the lowest: compounds 3, 2, 4 and 1 (each within the scatter of the next).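

In this assay the whole group at this position can be replaced by 2-methoxyphenyl and the compounds stay level: a 1.4-fold higher number from compound 3 to compound 4 (0.15 log units; within the scatter) and a 1.4-fold higher number from compound 2 to compound 4 (0.13 log units; within the scatter) and a 1.0-fold lower number from compound 1 to compound 4 (0.02 log units; within the scatter) all lie within the scatter. The earlier compounds shown here varied only a small group on the phenyl ring, whereas here the small group and its place on that ring both differ. No supporting measurement accounts for this level result. Still open, going by these compounds, is whether a phenyl ring carrying an amine or a carboxylic acid would stay level. A longer chain in place of the ring is equally untested among these compounds.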